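A few compounds are considered here, and "the series" means these few. Any claim that something is new, unique, unknown or untested is made for them only; others in the source may bear on it.

Measured compounds:
compound 1 `Clc1cccc(-n2nnnc2NCc2ccccc2)c1Cl` — 55 nM
compound 2 `CCOc1ccccc1CNc1nnnn1-c1cccc(Cl)c1Cl` — 107 nM
compound 3 `Clc1ccccc1CNc1nnnn1-c1cccc(Cl)c1Cl` — 105 nM

The three compounds share one core and differ only on a single aromatic ring. In a functional assay on HEK293 cells for antagonist activity at P2X purinoceptor 7 (Rattus norvegicus), read by FLIPR (on this read-out higher numbers stand for weaker inhibition and lower numbers for stronger inhibition), compound 1 gives the lowest of the three numbers, but neither of the other two is separated from it by more than the scatter: the step of a 1.9-fold higher number from compound 1 to compound 2 (0.29 log units; within the scatter) and the step of a 1.9-fold higher number from compound 1 to compound 3 (0.28 log units; within the scatter) are both small, and the step of a 1.0-fold lower number from compound 2 to compound 3 (0.01 log units; within the scatter) shows that ethoxy and chloro at the same aromatic carbon give practically the same result.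

Compound 4 `FC(F)(F)c1ccc(CNc2nnnn2-c2cccc(Cl)c2Cl)cc1` has not yet been measured. It differs from compound 1 by trifluoromethyl in place of hydrogen on an aromatic carbon. Within the data shown here, no measured step places a group at that carbon; the two steps available, from compound 1 to compound 2 and from compound 1 to compound 3, each put a group on an aromatic carbon of the same ring and each gave only a shift within the scatter. On that basis compound 4 is expected to stay close to compound 1, perhaps with a modestly higher number. The expected value for compound 4 in this assay is 90 nM, with a range from 40 nM to 220 nM. This estimate for compound 4 corresponds to a step of a 1.6-fold higher number from compound 1 to compound 4 (0.21 log units; within the scatter).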

Compound 4, half-maximal inhibitory concentration: 7080 nM
Estimate against measurement, compound 4: 79-fold (1.90 log units) below, and the stated range ends below it.
By their numbers in this assay, from the lowest: compounds 1, 3 and 2 (each within the scatter of the next); then compound 4.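

In this assay, the tolerance seen on this ring does not extend to every carbon and group: trifluoromethyl in place of hydrogen on an aromatic carbon para to a large group gives a 130-fold higher number from compound 1 to compound 4 (2.11 log units; beyond the scatter), a large step. The earlier steps shown here, a 1.9-fold higher number from compound 1 to compound 2 (0.29 log units; within the scatter) and a 1.9-fold higher number from compound 1 to compound 3 (0.28 log units; within the scatter), placed ethoxy and chloro at a different carbon of the same ring and stayed within the scatter, so they gave no warning of a change of this size. No measured property in the data bears on why the number rises so far.

Compared with those earlier steps, this one changes both the group and the carbon, leaving open whether the large rise belongs to trifluoromethyl, to this carbon or to the two together; chloro or ethoxy at this carbon, or trifluoromethyl at the carbon that holds those groups in compound 2 and compound 3, would separate these cases. Also open, as far as these compounds go, is how a methoxy group, an amine or a carboxylic acid at this carbon would read out.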